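Swapping a nitrile for an oxime on a shared core

This account rests on a few compounds, and the source may have more. Where it says the series, first, only, none or still open, it means among the compounds named here.

Compound 1 `N/C(S)=N/N=C/c1c(Cl)n(C2O[C@H](CO)[C@@H](O)[C@H]2O)c2cc(Cl)c(Cl)cc12` and compound 2 `N#Cc1c(Cl)n(C2O[C@H](CO)[C@@H](O)[C@H]2O)c2cc(Cl)c(Cl)cc12` share one core and differ only at one aromatic carbon. In a functional assay on KB cells (Homo sapiens) for cytotoxicity, read by spectrophotometry and crystal violet staining (a higher number here means a weaker inhibitor, a lower number a stronger inhibitor), compound 1 gives 65000 nM. In this assay compound 2 gives 65000 nM, so compound 2 stands level with compound 1, and the step of no change at the digits printed from compound 1 to compound 2 (within the scatter) shows that trading a larger group for a small one at that carbon left the read-out unchanged. Compound 3 `OC[C@H]1OC(n2c(Cl)c(/C=N/O)c3cc(Cl)c(Cl)cc32)[C@H](O)[C@@H]1O` is the next variation at the same place: a group of 3 heavy atoms (1 carbon, 1 nitrogen, 1 oxygen; no ring) in place of a group of 2 heavy atoms (1 carbon, 1 nitrogen; no ring), on an aromatic carbon. Within the data shown here, the only step that bears on this is the one from compound 1 to compound 2, which was flat, so a change of similar modest size at the same carbon is expected to stay within the scatter as well. Compound 3 is therefore estimated at 65000 nM in this assay, with a range from 30000 nM to 140000 nM, meaning an expected step of no change at the digits printed from compound 2 to compound 3 (within the scatter).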

Compound 3, half-maximal inhibitory concentration: 25000 nM
The estimate for compound 3 lay 2.6-fold (0.41 log units) above the measured number, and the stated range ends above it.
By their numbers in this assay, from the lowest: compound 3; then compounds 1 and 2 (each within the scatter of the next).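

In this assay, this aromatic carbon proves responsive to the group it carries: the oxime in place of the nitrile gives a 2.6-fold lower number from compound 2 to compound 3 (0.41 log units; beyond the scatter), and one oxygen atom in place of the larger group on the double-bonded nitrogen gives a 2.6-fold lower number from compound 1 to compound 3 (0.41 log units; beyond the scatter). The flat step of no change at the digits printed from compound 1 to compound 2 (within the scatter) therefore did not mean that changes here leave the read-out untouched, although the shift seen so far is modest and compound 3 remains a weak inhibitor by its number alone. Nothing given here explains the shift.

The compounds shown leave open whether the hydroxyl on the oxime matters, or whether the carbon-nitrogen double bond alone is enough. A methoxy on that nitrogen, or an aldehyde or a carboxylic acid at the same carbon, would help separate these possibilities.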